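From 1H-pyrazol-3-yl to 1-ethyl-1H-pyrazol-3-yl

The compounds below may be only part of what the source reports. "The series", "measured", "known", "first", "only" and "open" are said of these compounds alone.

Measured so far in a functional assay on HCT-116 cells (Homo sapiens) for inhibition; a lower number here means a stronger inhibitor, a higher number a weaker inhibitor
Compound 1 `CCNC(=O)c1noc(-c2cc(C(C)C)c(O)cc2O)c1-c1cc(C(=O)OCC)no1` gives "not determined" (no result reported)
Compound 2 `CCNC(=O)c1noc(-c2cc(C(C)C)c(O)cc2O)c1-c1cc(C(=O)NC)no1` gives 124 nM
Compound 3 `CCNC(=O)c1noc(-c2cc(C(C)C)c(O)cc2O)c1-c1cc[nH]n1` gives 36 nM

Compound 3 holds the lower of the two numbers, which makes it the stronger inhibitor of that pair, and compound 1 has no number. Compound 4 `CCNC(=O)c1noc(-c2cc(C(C)C)c(O)cc2O)c1-c1ccn(CC)n1` has ethyl in place of hydrogen on an aromatic nitrogen of compound 3, and ethyl in place of hydrogen on an aromatic nitrogen is the whole difference. Among the compounds with values here, the only measured step that bears on this is a 3.4-fold lower number from compound 2 to compound 3 (0.54 log units; beyond the scatter) and it exchanged a whole ring group, so it is a loose guide to size. Within the data shown here, no measured compound carries a group on this nitrogen. A smaller step toward a higher number is expected in this assay here, and a 2.2-fold higher number from compound 3 to compound 4 (0.35 log units; beyond the scatter) is the estimate. Compound 4 is expected at 80 nM with a range from 25 nM to 250 nM in this estimate.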

Compound 4, half-maximal inhibitory concentration: 25 nM
For compound 4 the middle estimate is 3.2-fold (0.51 log units) above the measured one, within the range that was stated.
By their numbers in this assay, from the lowest: compounds 4 and 3 (each within the scatter of the next); then compound 2.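

In this assay ethyl in place of hydrogen on the aromatic nitrogen gives a 1.4-fold lower number from compound 3 to compound 4 (0.16 log units; within the scatter) and so this nitrogen can carry a small chain with no loss of inhibition. The 1-ethyl-1H-pyrazol-3-yl group also stands clear of 3-(methylcarbamoyl)-1,2-oxazol-5-yl, with a 5.0-fold lower number from compound 2 to compound 4 (0.70 log units; beyond the scatter) as the step. No evidence is available to explain either result.

Still open, from the compounds shown here alone, is whether the same nitrogen accepts a longer chain, a benzyl group or a chain ending in an amine.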